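Removing a Fluorine from a Bombesin Receptor Agonist

A few compounds are considered here, and "the series" means these few. Any claim that something is new, unique, unknown or untested is made for them only; others in the source may bear on it.

Compound 1 `O=C(O)c1ccccc1-c1ccc(CCc2ncc(Cc3cccc(F)c3)[nH]2)cc1`: 159 nM
Compound 2 `CCCCc1cnc(C(CC)Cc2ccc(-c3ccccc3C(=O)O)cc2)[nH]1`: 2720 nM

In an in vitro functional assay on cells for agonist activity at Bombesin receptor subtype-3 (Homo sapiens), read by luminescence and calcium flux (on this read-out higher numbers stand for an effect only at larger amounts of compound and lower numbers for an effect already at smaller amounts), compound 1 gives 159 nM, the lowest of the two numbers; compound 2 gives 2720 nM, a higher number, beyond the usual scatter. Compound 3 `O=C(O)c1ccccc1-c1ccc(CCc2ncc(Cc3ccccc3)[nH]2)cc1` is not yet measured. It differs from compound 1 by hydrogen in place of fluoro on an aromatic carbon. Among the compounds with values here, no measured pair shows this change on its own, so only a small step is expected, if any beyond the scatter, leaning toward a higher number: a 1.6-fold higher number from compound 1 to compound 3 (0.21 log units; within the scatter). Compound 3 is therefore expected to give about 260 nM, between 100 nM and 700 nM.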

Compound 3, half-maximal effective concentration: 205 nM
The estimate for compound 3 lay 1.3-fold (0.10 log units) above the measured number; the range from low to high includes it.
By their numbers in this assay, from the lowest: compounds 1 and 3 (each within the scatter of the next); then compound 2.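

In this assay, going from 3-fluorobenzyl to benzyl gives a 1.3-fold higher number from compound 1 to compound 3 (0.11 log units; within the scatter), a step that stays within the usual scatter. Within the data shown here, this is the first direct look at this position, and it shows that the fluoro group on this aromatic carbon can be replaced by hydrogen without a change that stands out from the scatter. Compound 1 and compound 3 therefore cannot be ranked against each other.

Going by these compounds, it remains open whether a methoxy group, a chlorine or an amine at this place would also leave the number within the scatter. Nothing on hand explains why compound 1 and compound 3 read alike.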